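Methoxyphenyl Replaces Propylphenyl on the Amine Nitrogen

This account rests on a few compounds, and the source may have more. Where it says the series, first, only, none or still open, it means among the compounds named here.

Compound 1 `O=C1C(Nc2ccc(I)cc2)=CC(=O)c2c1nc1n2[C@H]2OC[C@@H](O)[C@H]2OC1`, compound 3 `O=C1C(Nc2ccc(Br)cc2)=CC(=O)c2c1nc1n2[C@H]2OC[C@@H](O)[C@H]2OC1` and compound 2 `CCCc1ccc(NC2=CC(=O)c3nc4n(c3C2=O)[C@H]2OC[C@@H](O)[C@H]2OC4)cc1` share one core and differ only in the aryl group on the amine nitrogen. In a functional assay on MGC-803 cells (Homo sapiens) for inhibition, read by sulforhodamine B assay (on this read-out lower numbers stand for stronger inhibition and higher numbers for weaker inhibition), compound 1 gives 2150 nM, compound 3 gives 2020 nM and compound 2 gives 1560 nM. Compound 2 has the lowest of these three numbers, yet its gaps to the other two lie within the scatter, so no order can be read from them. For the measured compounds named here, the only measured step, a 1.1-fold lower number from compound 1 to compound 3 (0.03 log units; within the scatter), exchanges one halogen for another and does not touch the change considered here. Compound 4 `COc1ccccc1NC1=CC(=O)c2nc3n(c2C1=O)[C@H]1OC[C@@H](O)[C@H]1OC3` differs from compound 2 by 2-methoxyphenyl in place of 4-propylphenyl on an amine nitrogen. Going by the values given here, no measured step bears on this change, so the expected step of a 1.3-fold higher number from compound 2 to compound 4 (0.11 log units; within the scatter) is none beyond the scatter, with a wide range. Compound 4 is therefore estimated at 2000 nM, between 900 nM and 4500 nM.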

Compound 4, half-maximal inhibitory concentration: 1630 nM
Beside the measured number, compound 4's estimate is 1.2-fold (0.09 log units) above it; the range from low to high includes it.
By their numbers in this assay, from the lowest: compounds 2, 4, 3 and 1 (each within the scatter of the next).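

Placing 2-methoxyphenyl where 4-propylphenyl stood on the amine nitrogen gives a 1.0-fold higher number from compound 2 to compound 4 (0.02 log units; within the scatter) in this assay, so these two numbers cannot be told apart. The earlier compounds shown here compared only aryl groups with a halogen or a propyl chain, while compound 4 shows that an aryl group carrying an oxygen-containing methoxy group also reads alike at this position. Going by these compounds, whether an aryl group bearing an amine or a carboxylic acid would read the same here remains open. No supporting evidence on this result is available.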